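The source may report more compounds than this note shows. Statements on the series, on what has been measured and on what is new or still open speak of the compounds shown alone.

Measured so far:
compound 1 `Cn1c(=O)c(=O)n(C2CCCC2)c2nc(N/N=C/c3ccc(S(C)(=O)=O)cc3)ncc21` — 26600 nM
compound 2 `Cn1c(=O)c(=O)n(C2CCCC2)c2nc(N/N=C/c3ccc(F)cc3Br)ncc21` — 9250 nM

In a functional assay on PC-3 cells (Homo sapiens) for antiproliferative activity, read by MTT assay (a lower number here means a stronger inhibitor, a higher number a weaker inhibitor), compound 1 stands with the highest of the two numbers, and the nearest measured compound is compound 2, reached by a 2.9-fold lower number from compound 1 to compound 2 (0.46 log units; beyond the scatter), a modest step beyond the scatter. Compound 3 `Cn1c(=O)c(=O)n(C2CCCC2)c2nc(N/N=C/c3ccc(F)cc3F)ncc21` is not yet measured. It differs from compound 1 in one place: 2,4-difluorophenyl in place of 4-(methylsulfonyl)phenyl on a carbon with a double bond to nitrogen. Among the compounds with values here, the only measured step that bears on this change is the one from compound 1 to compound 2, where a 2-bromo-4-fluorophenyl also replaced the 4-(methylsulfonyl)phenyl on the same carbon, giving a 2.9-fold lower number from compound 1 to compound 2 (0.46 log units; beyond the scatter). Within the data shown here, compound 3 carries a 2,4-difluorophenyl instead, so a step of similar size and direction is expected, though the single supporting step keeps the range wide. For compound 3 the estimated value in this assay is 12000 nM, with a range of 5000 nM to 30000 nM. This estimate corresponds to an expected step of a 2.2-fold lower number from compound 1 to compound 3 (0.35 log units; beyond the scatter).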

Compound 3, half-maximal inhibitory concentration: 13200 nM
Compound 3: the middle estimate sits 1.1-fold (0.04 log units) below what was measured; low and high end bracket the measured number.
By their numbers in this assay, from the lowest: compounds 2, 3 and 1 (each within the scatter of the next, the first and the last beyond it).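

In this assay, the change to 2,4-difluorophenyl on a carbon with a double bond to nitrogen gives a 2.0-fold lower number from compound 1 to compound 3 (0.30 log units; within the scatter), so unlike the earlier replacement by 2-bromo-4-fluorophenyl, this replacement of 4-(methylsulfonyl)phenyl cannot be told apart from repeat measurement. Fluoro in place of bromo on an aromatic carbon gives a 1.4-fold higher number from compound 2 to compound 3 (0.15 log units; within the scatter), so this swap of one halogen for the other shows no difference that can be read in these cells. Nothing available here offers an explanation for either result.

Going by these compounds, it remains open how an aryl group carrying an amine or a carboxylic acid would behave on this same carbon. On these data alone, all three compounds also share the same core, so the effect of any change outside this aryl group remains unknown.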